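The source may hold more compounds than are shown below. What is called first, only, known or untested is meant among the compounds shown, and "the series" means these compounds.

Measured in a functional assay on HEK293 cells (Homo sapiens) for cytotoxicity; a higher number here means that more compound is tolerated, a lower number that less compound is tolerated:
- compound 1 `COc1ccc([C@H]2CC(=O)N(Cc3cccc([N+](=O)[O-])c3)C2)cc1OC1CCCC1`; compound 1 gives > 10000 nM, a limit of the assay and not a number.
- compound 2 `COc1ccc([C@H]2CC(=O)N(C(=O)c3ccccc3)C2)cc1OC1CCCC1`; compound 2 gives > 10000 nM, likewise a limit.
- compound 3 `COc1ccc([C@H]2CC(=O)N(c3cccc(N(C)C)c3)C2)cc1OC1CCCC1`; compound 3 gives > 10000 nM, likewise a limit.

Compound 1 thus stands at the limit, and the two other values do the same (the limit of > 10000 nM in this assay, at which 3 of the 3 values shown sit). The unmeasured compound 4 `COc1ccc([C@H]2CC(=O)N(c3cccc(C)c3)C2)cc1OC1CCCC1` differs from compound 1 in one place: 3-methylphenyl in place of 3-nitrobenzyl on an amide-type nitrogen in a ring. The measured steps on this nitrogen are a step that the two limits leave unreadable from compound 1 to compound 2, a step that the two limits leave unreadable from compound 1 to compound 3 and a step that the two limits leave unreadable from compound 2 to compound 3; none of them yields a readable size, so no direction can be taken from them. Compound 4 is expected to give 20000 nM in this assay, with a range from 8000 nM to 60000 nM. The expected step that the limit leaves unreadable from compound 1 to compound 4 is estimated as none beyond the scatter, most likely reported again only as a limit.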

Compound 4, half-maximal cytotoxic concentration: > 10000 nM
Compound 4 ended at the assay's limit (the forecaster's own chance of this, stated with the estimate: 85%); the middle value does not contradict the limit.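

No step can be read among compound 1, compound 2, compound 3 and compound 4, as all four values are limits and not numbers: the limit of > 10000 nM in this assay, at which 4 of the 4 values shown sit.

The compounds shown leave open whether any group on this amide-type nitrogen changes the half-maximal cytotoxic concentration.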